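A few compounds are considered here, and "the series" means these few. Any claim that something is new, unique, unknown or untested is made for them only; others in the source may bear on it.

Working notes on the series in a functional assay on HCT-116 cells (Homo sapiens) for antiproliferative activity, read by MTT assay, with a stated time of 48 h; on this read-out higher numbers stand for weaker inhibition and lower numbers for stronger inhibition. Compound 1 `N#CC1=C(N)Oc2c(c3nc4ccccc4nc3c3ccccc23)C12C(=O)N(Cc1cnnn1-c1ccc([N+](=O)[O-])cc1)c1ccccc12` sits at the limit of this assay, giving > 50000 nM, which is a limit and not a number. Compound 2 `Cc1ccc(C)c(-n2nncc2CN2C(=O)C3(C(C#N)=C(N)Oc4c3c3nc5ccccc5nc3c3ccccc43)c3ccccc32)c1` likewise sits at the limit, with > 50000 nM. The step in this assay a step that the two limits leave unreadable from compound 1 to compound 2, with 2,5-dimethylphenyl in place of 4-nitrophenyl on an aromatic nitrogen, cannot be sized, as both of its values are limits.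

Compound 3 `Cc1cccc(-n2nncc2CN2C(=O)C3(C(C#N)=C(N)Oc4c(N)cc5nc6ccccc6nc5c43)c3ccccc32)c1` stands at the same limit of this assay, with > 50000 nM, again a limit rather than a number. Among the measured compounds shown here, every value shown sits at the limit of > 50000 nM in this assay, at which 3 of the 3 values shown sit, so no step among compounds 1, 2 and 3 can be read.

Compound 4 `N#CC1=C(N)Oc2c(N)cc3nc4ccccc4nc3c2C12C(=O)N(Cc1cnnn1-c1cc(Cl)ccc1Cl)c1ccccc12` is not yet measured. It differs from compound 3 by 2,5-dichlorophenyl in place of 3-methylphenyl on an aromatic nitrogen. For the measured compounds named here, no readable measured step bears on this change; the single recorded step is unreadable. Nothing in the series shows activity within the range of this assay, so the step expected here, a number no higher from compound 3 to compound 4 (the limit leaves the size open), is none beyond the scatter, with the value most likely once more a limit. Compound 4 is therefore expected to give about 50000 nM in this assay, within the range 20000 nM to 100000 nM.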

Compound 4, half-maximal inhibitory concentration: > 50000 nM
Compound 4: no number, only a limit; the forecaster's own chance of this, stated with the estimate: 80%; the middle value lies on the limit itself.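

In this assay compound 4 gives > 50000 nM as a limit and not a number. Among the compounds shown here, no step among compounds 1, 2, 3 and 4 can be read, with every value a limit: the limit of > 50000 nM in this assay, at which 4 of the 4 values shown sit. In this assay the compounds shown leave open how any of these changes would read inside the measurable range.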